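This account rests on a few compounds, and the source may have more. Where it says the series, first, only, none or still open, it means among the compounds named here.

Measured so far:
Compound 1, `Nc1n[nH]c2cc(-c3cn([C@@H]4CN[C@H](C(=O)Nc5ccc(Cl)c(C(F)(F)F)c5)C4)nn3)ccc12`: in a functional assay on K562/Adr cells (Homo sapiens) for inhibition, read by MTT assay, with a stated time of 48 h, tested at 30 uM (a higher number here means more inhibition at the concentration tested (going by the name of the read-out), a lower number less inhibition), compound 1 gives 48.2%.
Compound 2, `Nc1n[nH]c2cc(-c3cn([C@@H]4CN[C@H](C(=O)Nc5ccc(Cl)cc5Cl)C4)nn3)ccc12`: in this assay compound 2 gives 29.4%.

Compound 2 stands lowest of the two numbers shown; its nearest neighbour is compound 1, and the one measured step, a number 18.8 percentage points lower from compound 1 to compound 2 (beyond the scatter), is beyond the scatter.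

Compound 3, `Nc1n[nH]c2cc(-c3cn([C@@H]4CN[C@H](C(=O)Nc5ccc(Br)cc5)C4)nn3)ccc12`, is not yet measured. It differs from compound 2 by 4-bromophenyl in place of 2,4-dichlorophenyl on an amide-type nitrogen.

For the measured compounds named here, no measured step bears directly on this change. Going by the values given here, the single step, from compound 1 to compound 2, exchanges one substituted phenyl for another on the same amide-type nitrogen and was of modest size, but it does not involve 4-bromophenyl, so it only shows that this part of the molecule can move the read-out by a modest amount in either direction. On that basis, no step beyond the scatter is expected for compound 3 in this assay, with the expected step being a number 2.6 percentage points higher from compound 2 to compound 3 (within the scatter).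

Compound 3 is therefore estimated at 32% in this assay, within an expected range of 15% to 50%.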

Compound 3, a percentage reported as inhibition, at one concentration (the size of the read-out at that concentration, not a potency): 26.8%
Compound 3: the middle estimate sits 5.2 percentage points above what was measured; the range from low to high includes it.
By their numbers in this assay, from the lowest: compounds 3 and 2 (each within the scatter of the next); then compound 1.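

In this assay, with a number 2.6 percentage points lower from compound 2 to compound 3 (within the scatter), the two groups on the amide-type nitrogen cannot be told apart, even though 4-bromophenyl carries one bromine where 2,4-dichlorophenyl carries two chlorines. With a number 21.4 percentage points lower from compound 1 to compound 3 (beyond the scatter), a second replacement of 4-chloro-3-(trifluoromethyl)phenyl now falls beyond the scatter, so among these three compounds, compound 1 stands apart from both compound 2 and compound 3, and the earlier single step no longer rests on one comparison alone. Nothing on hand explains why these groups read as they do.

The three groups differ in more than one feature, so these compounds do not separate the part played by the trifluoromethyl group from that of the chlorine or bromine, and a 3-(trifluoromethyl)phenyl or a 4-chlorophenyl on the same nitrogen would bear directly on that. Also open, as far as these compounds go, is how this assay would read with groups unlike these halogenated rings at this position, such as an unsubstituted phenyl, a phenyl carrying a methoxy group or a carboxylic acid, or a cyclohexyl ring.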